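The source may report more compounds than this note shows. Statements on the series, on what has been measured and on what is new or still open speak of the compounds shown alone.

In a functional assay on HeLa cells (Homo sapiens) for cytotoxicity, read by MTT assay, with a stated time of 48 h (a lower number here means a stronger inhibitor, a higher number a weaker inhibitor), the measured compounds give these values:

- compound 1 `O=C(O)CN1C(=O)/C(=C/c2nc3ccccc3n2Cc2ccc(Cl)cc2)SC1=S` gives 8720 nM
- compound 2 `O=C(O)CN1C(=O)/C(=C/c2nc3ccccc3n2Cc2ccc(C(F)(F)F)cc2)SC1=S` gives 21400 nM

Compound 2 has the higher of the two numbers, which makes it the weaker inhibitor of the pair. Within the data shown here, only one measured step bears on what comes next (a 2.5-fold higher number from compound 1 to compound 2 (0.39 log units; beyond the scatter)). It is modest but beyond the usual scatter, and it came with trifluoromethyl in place of chloro on an aromatic carbon.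

Compound 3 `O=C(O)CN1C(=O)/C(=C/c2nc3ccccc3n2Cc2ccc(F)c(F)c2)SC1=S` carries 3,4-difluorophenyl in place of 4-(trifluoromethyl)phenyl on a saturated chain carbon bound to an aromatic nitrogen. The trifluoromethyl group therefore goes, and the number may fall back towards that of compound 1 (8720 nM). Among the measured compounds shown here, no compound with fluorine on this ring has been measured, so this rests on a single step. In this assay the expected change is a modest fall (a 1.9-fold lower number from compound 2 to compound 3 (0.29 log units; within the scatter)), and it could still prove to lie within the scatter. Compound 3 is expected at 11000 nM (estimated range 4500 nM to 27000 nM).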

Compound 3, half-maximal inhibitory concentration: 16000 nM
The estimate for compound 3 lay 1.5-fold (0.16 log units) below the measured number, within the range that was stated.
By their numbers in this assay, from the lowest: compounds 1, 3 and 2 (each within the scatter of the next, the first and the last beyond it).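

In this assay the position on a saturated chain carbon bound to an aromatic nitrogen now has a third ring: 3,4-difluorophenyl in place of 4-(trifluoromethyl)phenyl gives a 1.3-fold lower number from compound 2 to compound 3 (0.13 log units; within the scatter) and 3,4-difluorophenyl in place of 4-chlorophenyl gives a 1.8-fold higher number from compound 1 to compound 3 (0.26 log units; within the scatter) in this series. Compounds 1 and 2 could be told apart, but compound 3 lies within the scatter of both, so these data cannot place it closer to either one. No supporting measurement is available to explain this result.

From the compounds shown here alone, it remains open whether a phenyl ring carrying an amine or a methoxy group would give a number clearly outside the scatter of these three compounds. The effect of a longer chain at this saturated carbon is also unknown.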